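Carbonyl substituent and cytotoxicity in the shared core

The compounds below may be only part of what the source reports. "The series", "measured", "known", "first", "only" and "open" are said of these compounds alone.

Compound 3 `O=C(OCCc1c(-c2ccccc2Cl)c2cc(Cl)ccc2[nH]c1=O)c1ccc([N+](=O)[O-])cc1` gives 1600000 nM in an ADME assay on HepG2 2.2.15 cells (Homo sapiens) for cytotoxicity (a lower number here means that less compound is tolerated, a higher number that more compound is tolerated), the highest of the three numbers in hand. Compound 1 `O=C(O)CCCC(=O)OCCc1c(-c2ccccc2Cl)c2cc(Cl)ccc2[nH]c1=O` gives 110000 nM in this assay, and compound 2 `COCC(=O)OCCc1c(-c2ccccc2Cl)c2cc(Cl)ccc2[nH]c1=O` gives 74000 nM in this assay. Between the first two the step of a 1.5-fold lower number from compound 1 to compound 2 (0.17 log units; within the scatter) stays within the scatter, whereas a 15-fold higher number from compound 1 to compound 3 (1.16 log units; beyond the scatter) and a 22-fold higher number from compound 2 to compound 3 (1.33 log units; beyond the scatter) are both large, so the group on the carbonyl carbon is where the series moves.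

Compound 4 `COc1ccc(/C=C/C(=O)OCCc2c(-c3ccccc3Cl)c3cc(Cl)ccc3[nH]c2=O)cc1` has not yet been measured in this assay. It differs from compound 3 in 2-(4-methoxyphenyl)ethenyl in place of 4-nitrophenyl on a carbonyl carbon. The two large steps bear on this change only in part: each of them brings a six-membered aromatic ring of carbon only onto the carbonyl carbon in place of a chain, and compound 4 keeps such a ring, so those steps do not point to a return toward compound 1 or compound 2. Among the measured compounds shown here, no measured pair exchanges one ring-bearing group for another, and the effect of the added ethenyl link is unknown. The expectation for this assay is therefore a step of a 1.6-fold lower number from compound 3 to compound 4 (0.20 log units; within the scatter), not beyond the scatter, with the direction open. Compound 4 is estimated at 1000000 nM, with a range from 300000 nM to 3000000 nM.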

Compound 4, half-maximal cytotoxic concentration: > 1200000 nM
Compound 4: a limit, no number; the forecaster's own chance of this, stated with the estimate: 30%; at least 1.2-fold (0.07 log units) between middle value and limit.
By their numbers in this assay, from the lowest: compounds 2 and 1 (each within the scatter of the next); then compound 3.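

Working notes on the group on the carbonyl carbon. In this assay, a second group carrying a six-membered aromatic ring of carbon only, 2-(4-methoxyphenyl)ethenyl, also stands clear of the two chain groups: an at least 16-fold higher number from compound 2 to compound 4 (1.20 log units; beyond the scatter) and an at least 10-fold higher number from compound 1 to compound 4 (1.03 log units; beyond the scatter). Among these compounds, the high end of the series therefore no longer rests on 4-nitrophenyl alone, and both ring-bearing groups go with the higher numbers, with neither compound 3 nor compound 4 going against that pattern. Compound 4 carries a limit and not a number, so its step from compound 3 cannot be read: the limit of > 1200000 nM in this assay, at which 1 of the 4 values shown sits.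

Whether the ring alone accounts for the separation stays open, since a plain phenyl group on the carbonyl carbon or a saturated 2-phenylethyl group in place of the ethenyl-linked one would be needed to tell the ring from its link. Also open, going by these compounds, is whether a long unbranched alkyl chain or an amine-bearing chain on the same carbonyl carbon would sit with compound 1 and compound 2 or with the ring-bearing pair.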